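The compounds below may be only part of what the source reports. "The series", "measured", "known", "first", "only" and "open" are said of these compounds alone.

In a functional assay on NCI-H661 cells (Homo sapiens) for cytotoxicity, read by WST assay, with a stated time of 72 h (on this read-out higher numbers stand for weaker inhibition and lower numbers for stronger inhibition), compound 1 `CCN(CC)CCCOc1cc2ncnc(Nc3nc4ccc(C(=O)Nc5c(C)cccc5Cl)cc4s3)c2cc1OC` gives 11200 nM, and compound 2 `CCN(CC)CCCOc1cc2ncnc(Nc3nc4ccc(C(=O)Nc5c(C)cc(C)cc5C)cc4s3)c2cc1OC` gives 7300 nM. Compound 3 `COc1cc2c(Nc3nc4ccc(C(=O)Nc5c(C)cccc5Cl)cc4s3)ncnc2cc1OCCCN1CCCCC1` gives 13800 nM in this assay. The core of compound 3 differs from the core of compound 1 by piperidin-1-yl in place of diethylamino on a saturated chain carbon, three bonds along the chain from an oxygen on an aromatic ring, a change that made a 1.2-fold higher number from compound 1 to compound 3 (0.09 log units; within the scatter). Compound 4 `COc1cc2c(Nc3nc4ccc(C(=O)Nc5c(C)cc(C)cc5C)cc4s3)ncnc2cc1OCCCN1CCCCC1` has not yet been measured in this assay. It differs from compound 3 by 2,4,6-trimethylphenyl in place of 2-chloro-6-methylphenyl on an amide-type nitrogen. The same change, (2,4,6-trimethylphenyl in place of 2-chloro-6-methylphenyl on an amide-type nitrogen), on the core of compound 1 made a 1.5-fold lower number from compound 1 to compound 2 (0.19 log units; within the scatter). Because a 1.5-fold lower number from compound 1 to compound 2 (0.19 log units; within the scatter) was seen on the other core, and because a 1.2-fold higher number from compound 1 to compound 3 (0.09 log units; within the scatter) shows the two cores giving numbers close to each other, the step from compound 3 to compound 4 is expected to be of a similar size, a 1.5-fold lower number from compound 3 to compound 4 (0.18 log units; within the scatter). Compound 4 is therefore estimated to give about 9200 nM in this assay, expected to lie between 5000 nM and 18000 nM.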

Compound 4, half-maximal inhibitory concentration: 10000 nM
Estimate against measurement, compound 4: 1.1-fold (0.04 log units) below; the measured number falls inside the stated range.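

In this assay, 2,4,6-trimethylphenyl in place of 2-chloro-6-methylphenyl on the amide-type nitrogen gives a 1.4-fold lower number from compound 3 to compound 4 (0.14 log units; within the scatter), a step that matches the one seen on the other core: the same change on two cores in this assay, a 1.5-fold lower number (0.19 log units; within the scatter) from compound 1 to compound 2 and a 1.4-fold lower number (0.14 log units; within the scatter) from compound 3 to compound 4, 1.1-fold (0.05 log units) apart, within the scatter of two such steps

Piperidin-1-yl in place of diethylamino gives a 1.4-fold higher number from compound 2 to compound 4 (0.14 log units; within the scatter), which also matches its earlier counterpart: the same change on two cores in this assay, a 1.2-fold higher number (0.09 log units; within the scatter) from compound 1 to compound 3 and a 1.4-fold higher number (0.14 log units; within the scatter) from compound 2 to compound 4, 1.1-fold (0.05 log units) apart, within the scatter of two such steps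

Both changes therefore carried from one core to the other without a detectable difference, but all of these steps lie within the scatter, so the data do not show that either change has a real effect of its own or that such carrying over holds beyond these four compounds.

The compounds shown leave open whether a morpholin-4-yl or 4-methylpiperazin-1-yl group in place of piperidin-1-yl, or a longer chain, would move the number beyond the scatter. As far as these compounds go, it also remains open how an unsubstituted phenyl on the amide-type nitrogen would behave.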